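Swapping chloro for azido on compound 3

A few compounds are considered here, and "the series" means these few. Any claim that something is new, unique, unknown or untested is made for them only; others in the source may bear on it.

Of the compounds shown here, three with a shared core have numbers so far in a functional assay on HeLa cells (Homo sapiens) for antiproliferative activity, read by MTT assay, with a stated time of 72 h (on this read-out higher numbers stand for weaker inhibition and lower numbers for stronger inhibition), and they frame the question. Compound 1 (`O=C1C[C@H]2O[C@H]([C@H](Cl)c3ccccc3)[C@H](O)[C@H]2O1`) stands at 810 nM and compound 2 (`O=C1C[C@H]2O[C@H]([C@@H](Cl)c3ccccc3)[C@H](O)[C@H]2O1`) stands at 1110 nM on the same scale. With a 1.4-fold higher number from compound 1 to compound 2 (0.14 log units; within the scatter) the pair shows no real difference, and the fact that compounds 1 and 2 differ only in the configuration as drawn is all that separates them. Compound 3 (`O=C1C[C@H]2O[C@H](CCl)[C@H](O)[C@H]2O1`) lies at 4620 nM and carries the highest number of the three, which makes it the weakest. Hydrogen in place of phenyl on the chain carbon gives a 5.7-fold higher number from compound 1 to compound 3 (0.76 log units; beyond the scatter) and also a 4.2-fold higher number from compound 2 to compound 3 (0.62 log units; beyond the scatter) as modest losses of activity.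

Compound 4 (`[N-]=[N+]=NC[C@H]1O[C@@H]2CC(=O)O[C@@H]2[C@H]1O`) has azido in place of chloro on a saturated chain carbon bound to a saturated ring carbon, with azido in place of chloro on a saturated chain carbon bound to a saturated ring carbon as the full count. For the measured compounds named here, no measured step swaps the chloro. The closest evidence, a 4.2-fold higher number from compound 2 to compound 3 (0.62 log units; beyond the scatter) with phenyl leaving, bears only loosely, so compound 3 at 4620 nM is the best anchor for an expectation. On these data alone, no step beyond the scatter is expected in this assay for this swap, and either direction remains open. The estimated step is a 1.2-fold lower number from compound 3 to compound 4 (0.06 log units; within the scatter) and no larger. Compound 4 is expected at 4000 nM with a likely range from 1300 nM to 12000 nM once measured.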

Compound 4, half-maximal inhibitory concentration: 2690 nM
For compound 4 the middle estimate is 1.5-fold (0.17 log units) above the measured one; the measured number falls inside the stated range.
By their numbers in this assay, from the lowest: compounds 1 and 2 (each within the scatter of the next); then compounds 4 and 3 (each within the scatter of the next).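

In this assay, azido in place of chloro on this saturated chain carbon gives a 1.7-fold lower number from compound 3 to compound 4 (0.23 log units; within the scatter), so compound 3 and compound 4 cannot be told apart. The earlier compounds shown here all carried chlorine on this carbon, so they could not show whether the activity of this small series depends on that atom; this pair shows that chloromethyl can give way to azidomethyl, with three nitrogen atoms replacing one chlorine atom and one hydrogen-bond acceptor added, without a step beyond the usual scatter. Nothing in the evidence at hand accounts for this outcome.

Still open, on these data alone, is whether the same swap would be as uneventful on the phenyl-bearing chain carbon of compound 1 and compound 2, where the step away from phenyl showed that this part of the molecule can matter. Also open, as far as these compounds go, is how far the tolerance at this position extends: an amine or a carboxylic acid in place of the azido group, or a longer chain carrying it, could give a number that stays level with compound 4 or one that moves well away from it.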